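Compound 1 to compound 4: a ring group exchanged

The compounds below may be only part of what the source reports. "The series", "measured", "known", "first", "only" and "open" are said of these compounds alone.

Measured in an ADME assay on microsomes from liver (Mus musculus) for metabolic stability; a lower number here means that the compound disappears faster, a higher number that the compound lasts longer:
- compound 1 `CC(C)C(c1ccc(-c2ccc3cccc(F)c3c2)[nH]c1=O)N1CCCCS1(=O)=O`: 0.0733 h
- compound 2 `CCn1ncc2c(F)cc(-c3ccc(C(CC)(CC)c4nnc[nH]4)c(=O)[nH]3)cc21`: > 3 h (a limit)
- compound 3 `CCn1ncc2c(F)cc(-c3ccc(C(CC)(CC)c4nnc(C)[nH]4)c(=O)[nH]3)cc21`: > 3 h (a limit)

Going by the values given here, compound 1 holds the only readable number, and it is the starting point here. Compound 4 `CC(C)C(c1ccc(-c2ccc3cccc(F)c3c2)[nH]c1=O)N1CCN/C1=N\C#N` is not yet measured. The change is a group of 8 heavy atoms (4 carbon, 4 nitrogen; one five-membered non-aromatic ring with 2 hetero atoms) in place of a group of 8 heavy atoms (4 carbon, 1 nitrogen, 2 oxygen, 1 sulfur; one six-membered non-aromatic ring with 2 hetero atoms), on a saturated chain carbon bound to an aromatic carbon and a saturated chain carbon. Among the compounds with values here, the only measured step is a step that the two limits leave unreadable from compound 2 to compound 3, a different change that gives no size to carry over. No step beyond the scatter in this assay can therefore be argued, and no direction is expected, so the estimate stays near compound 1 at 0.0733 h. The expected step is a 1.6-fold higher number from compound 1 to compound 4 (0.21 log units; within the scatter). For compound 4 the estimated half-life is 0.12 h, with an expected range of 0.05 h to 0.5 h.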

Compound 4, half-life: 0.207 h
The estimate for compound 4 lay 1.7-fold (0.24 log units) below the measured number; measured number inside the range.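

In this assay the ring exchange on the saturated chain carbon gives the series its first readable size: a 2.8-fold higher number from compound 1 to compound 4 (0.45 log units; beyond the scatter). The earlier step between compound 2 and compound 3 cannot be read, so this place is the only one shown to respond to a change. Compound 2 and compound 3 each stand at a limit of the assay, not at a number: the limit of > 3 h in this assay, at which 2 of the 4 values shown sit.

As far as these compounds go, the exchange alters ring size, ring hetero atoms and the nitrile together, and which of these carries the step stays open. From the compounds shown here alone, how an open-chain amine or a carboxylic acid on the same carbon would read also stays open.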